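The source may hold more compounds than are shown below. What is called first, only, known or untested is meant among the compounds shown, and "the series" means these compounds.

The compounds measured so far are:

compound 1, `Nc1nc(-c2ccco2)nc2sc(CNC3CC3)cc12`, giving 1890 nM in an assay on CHO-K1 cells for antagonist activity at adenosine receptor A1 (Homo sapiens), read by a beta-galactosidase reporter, with stated times of 15 min and 6 h; a higher number here means a weaker inhibitor, a lower number a stronger inhibitor;
compound 2, `Nc1nc(-c2ccco2)nc2sc(CN3CC=CCC3)cc12`, giving 150 nM;
compound 3, `Nc1nc(-c2ccco2)nc2sc(CN3CCC(=O)CC3)cc12`, giving 2720 nM.

Compound 2 stands lowest of the three. The steps of a 13-fold lower number from compound 1 to compound 2 (1.10 log units; beyond the scatter) and an 18-fold higher number from compound 2 to compound 3 (1.26 log units; beyond the scatter) both lie beyond the scatter, whereas the step of a 1.4-fold higher number from compound 1 to compound 3 (0.16 log units; within the scatter) stays within it, so compound 1 and compound 3 cannot be ordered against each other.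

Compound 4, `Nc1nc(-c2cocn2)nc2sc(CN3CC=CCC3)cc12`, keeps the group of compound 2 on the saturated chain carbon bound to an aromatic carbon and changes the aromatic substituent on the shared core: 1,3-oxazol-4-yl in place of furan-2-yl on an aromatic carbon

For the measured compounds named here, none of the measured steps touches this position; all three vary only the group on the saturated chain carbon and keep furan-2-yl in place. They give no direct guide to the size of the new step, and the change swaps one five-membered aromatic ring for another of the same size. A step of no more than modest size in this assay is expected, in the direction of a somewhat higher number. Compound 4 is expected to give about 350 nM, within a range of 100 nM to 1200 nM. This estimate amounts to a step of a 2.3-fold higher number from compound 2 to compound 4 (0.37 log units; beyond the scatter).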

Compound 4, inhibition constant: 2960 nM
For compound 4 the middle estimate is 8.5-fold (0.93 log units) below the measured one; measured number above the stated range.
By their numbers in this assay, from the lowest: compound 2; then compounds 1, 3 and 4 (each within the scatter of the next).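

In this assay, a change at the aromatic carbon between two ring nitrogen atoms proves able to move the number by a large step: 1,3-oxazol-4-yl in place of furan-2-yl gives a 20-fold higher number from compound 2 to compound 4 (1.30 log units; beyond the scatter). The earlier steps shown here varied only the group on the saturated chain carbon, so they could not show that this position responds strongly even when one five-membered aromatic ring replaces another with the same count of heavy atoms, the entering ring having 2 hydrogen-bond acceptors against 1 in the ring that leaves. Nothing available here accounts for the size of this step.

Still open, on these data alone, is whether the step would keep its size with the 4-oxopiperidin-1-yl group of compound 3 on the saturated chain carbon. Also open, as far as these compounds go, is how a thiophen-2-yl or a phenyl ring at this position would compare with furan-2-yl.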